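Halogen swap on a fused pentacyclic series: expected step

This account rests on a few compounds, and the source may have more. Where it says the series, first, only, none or still open, it means among the compounds named here.

Measured so far in a functional assay on SW1573 cells (Homo sapiens) for inhibition, read by sulforhodamine B assay, with a stated time of 48 h; on this read-out higher numbers stand for weaker inhibition of growth and lower numbers for stronger inhibition of growth:
compound 1 `COC(=O)[C@@]1(C)CC[C@@H]2C3=C1CC[C@@H](C)[C@]3(C)C[C@@H]1c3cccc(Br)c3N[C@H]21` gives 44000 nM
compound 2 `COC(=O)[C@@]1(C)CC[C@@H]2C3=C1CC[C@@H](C)[C@]3(C)C[C@@H]1c3cccc(Cl)c3N[C@H]21` gives 49000 nM
compound 3 `COC(=O)[C@@]1(C)CC[C@@H]2C3=C1CC[C@@H](C)[C@]3(C)Cc1c2[nH]c2c(Br)cccc12` gives 26000 nM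

Compound 2 differs from compound 1 by chloro in place of bromo on an aromatic carbon, and this gave a 1.1-fold higher number from compound 1 to compound 2 (0.05 log units; within the scatter). Compound 3 carries a different core; the difference between the two cores is not broken down here, and its value sits within the scatter of compound 1 and compound 2. Compound 4 `COC(=O)[C@@]1(C)CC[C@@H]2C3=C1CC[C@@H](C)[C@]3(C)Cc1c2[nH]c2c(Cl)cccc12` is not yet measured. It differs from compound 3 by chloro in place of bromo on an aromatic carbon, the same change made from compound 1 to compound 2, at a place described in the same words. Because a 1.1-fold higher number from compound 1 to compound 2 (0.05 log units; within the scatter) lay within the scatter, a step of about a 1.1-fold higher number from compound 3 to compound 4 (0.05 log units; within the scatter) is expected here too. Compound 4 is therefore estimated at 29000 nM, with a likely range from 15000 nM to 55000 nM.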

Compound 4, concentration for 50% growth inhibition: 17000 nM
Compound 4: the middle estimate sits 1.7-fold (0.23 log units) above what was measured, and the stated range covers the measured number.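

In this assay, chloro in place of bromo on an aromatic carbon gave a 1.5-fold lower number from compound 3 to compound 4 (0.18 log units; within the scatter), so the swap again produced no step beyond the scatter. Set beside the earlier step, the change shows no difference between the two cores: the same change on two cores in this assay, a 1.1-fold higher number (0.05 log units; within the scatter) from compound 1 to compound 2 and a 1.5-fold lower number (0.18 log units; within the scatter) from compound 3 to compound 4, 1.7-fold (0.23 log units) apart, within the scatter of two such steps. This supports treating bromo and chloro as interchangeable at this place on these two cores only; it does not show that the two steps are identical, or that the same would hold on any other core.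

The compounds shown leave open whether an amine, a methoxy group or a nitrile at this place would give a step beyond the scatter. They also leave open what a carboxylic acid in place of the methyl ester would do.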